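The compounds below may be only part of what the source reports. "The series", "measured", "known", "first", "only" and "open" are said of these compounds alone.

Three analogues on one core are in hand: compound 1 `CCOC(=O)c1c(-c2ccccc2)[nH]c2cc(OC)ccc2c1=O`, compound 2 `CCOC(=O)c1c(-c2cccc(-c3ccccc3)c2)[nH]c2cc(OC)ccc2c1=O` and compound 3 `CCOC(=O)c1c(-c2cccc(OCC(C)C)c2)[nH]c2cc(OC)ccc2c1=O`. In an ADME assay on HepG2 cells (Homo sapiens) for cytotoxicity, read by luminescence, with a stated time of 72 h (on this read-out lower numbers stand for an effect already at smaller amounts and higher numbers for an effect only at larger amounts of compound), compound 1 gives only a limit, > 21500 nM. Compound 2 also gives a limit in this assay, > 21500 nM. Compound 3 stands at a limit in this assay as well, > 21500 nM. All three therefore rest at the limit of > 21500 nM in this assay, at which 3 of the 3 values shown sit, and the steps a step that the two limits leave unreadable from compound 1 to compound 2, a step that the two limits leave unreadable from compound 1 to compound 3 and a step that the two limits leave unreadable from compound 2 to compound 3 cannot be sized. Next is compound 4 `CCOC(=O)c1c(-c2cccc(S(C)(=O)=O)c2)[nH]c2cc(OC)ccc2c1=O`, differing from compound 3 as follows: methylsulfonyl in place of isobutoxy on an aromatic carbon. With no readable step to lean on, the expected step in this assay is a step that the limit leaves unreadable from compound 3 to compound 4, nothing beyond the scatter. Compound 4 is thus expected near 30000 nM, between 15000 nM and 90000 nM.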

Compound 4, half-maximal effective concentration: > 21500 nM
Compound 4 was reported as a limit; the forecaster's own chance of this, stated with the estimate: 80%; the middle value is on the limit's open side.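

Compound 4 adds no readable step against compound 1, compound 2 or compound 3 in this assay: the limit of > 21500 nM in this assay, at which 4 of the 4 values shown sit.

The compounds shown leave open how the hydrogen, phenyl, isobutoxy and methylsulfonyl variants compare, and whether any change on the shared core gives a measurable effect.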